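Amino-acid amide tail on the shared core

This account rests on a few compounds, and the source may have more. Where it says the series, first, only, none or still open, it means among the compounds named here.

Compound 3 `CCOC(=O)CN(C)C(=O)c1ccc(C(CC)(CC)c2ccc(OCCC(O)(CC)CC)c(C)c2)n1CC` shows the lowest of the two numbers obtained in an assay on cells for agonist activity at vitamin D3 receptor (Homo sapiens), with a stated time of 96 h (on this read-out higher numbers stand for an effect only at larger amounts of compound and lower numbers for an effect already at smaller amounts), where compound 3 gives 520 nM. Its nearest neighbour is compound 1 `C#CCCOC(=O)c1ccc(C(CC)(CC)c2ccc(OCCC(O)(CC)CC)c(C)c2)n1CC`, which in this assay gives 6030 nM, so that there is a 12-fold lower number from compound 1 to compound 3 (1.06 log units; beyond the scatter). Compound 2 `CCC(C)C(NC(=O)c1ccc(C(CC)(CC)c2ccc(OCCC(O)(CC)CC)c(C)c2)n1CC)C(=O)OC` gives in this assay only a limit, > 10000 nM. Compound 4 `CCn1c(C(=O)NC(C)C(=O)O)ccc1C(CC)(CC)c1ccc(OCCC(O)(CC)CC)c(C)c1` carries (1-carboxyethyl)amino in place of ((ethoxycarbonyl)methyl)(methyl)amino on a carbonyl carbon. Within the data shown here, two measured steps bear on it, a 12-fold lower number from compound 1 to compound 3 (1.06 log units; beyond the scatter) and an at least 19-fold lower number from compound 2 to compound 3 (1.28 log units; beyond the scatter); both ran toward compound 3, so a change away from its tail is expected to raise the number, though its size remains uncertain. For compound 4 the expected value is 3000 nM, with a range from 500 nM to 20000 nM. This expectation amounts to a 5.8-fold higher number from compound 3 to compound 4 (0.76 log units; beyond the scatter).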

Compound 4, half-maximal effective concentration: 66 nM
For compound 4 the middle estimate is 45-fold (1.66 log units) above the measured one; measured number below the stated range.
By their numbers in this assay, from the lowest: compound 4; then compound 3; then compound 1. At a limit, above all of these: compound 2.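

On a carbonyl carbon, (1-carboxyethyl)amino in place of ((ethoxycarbonyl)methyl)(methyl)amino gives a 7.9-fold lower number from compound 3 to compound 4 (0.90 log units; beyond the scatter) in this assay, the first tail shown that ends in a carboxylic acid rather than an ester. The same tail also gives a 91-fold lower number from compound 1 to compound 4 (1.96 log units; beyond the scatter), and on the amide-type nitrogen, an at least 150-fold lower number from compound 2 to compound 4 (2.18 log units; beyond the scatter). That last step is only a floor, since compound 2 stands at a limit: the limit of > 10000 nM in this assay, at which 1 of the 4 values shown sits.

On these data alone, the step from compound 3 changes the ester and the methyl on the amide nitrogen together, so what each contributes stays open. Also open, as far as these compounds go, is how a longer chain in place of the methyl on the carboxyethyl group would read.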